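The source may report more compounds than this note shows. Statements on the series, on what has been measured and on what is new or still open speak of the compounds shown alone.

In a functional assay on HT-29 cells (Homo sapiens) for inhibition, read by sulforhodamine B assay, with a stated time of 72 h (a lower number here means a stronger inhibitor, a higher number a weaker inhibitor), the three measured compounds give these numbers: compound 1 `C=CC1C(=O)N(c2cc(OC)c(OC)c(OC)c2)C1c1ccc(OC)cc1` gives 10 nM; compound 2 `CCOc1ccc(C2C(Oc3ccccc3)C(=O)N2c2cc(OC)c(OC)c(OC)c2)cc1` gives 388 nM; compound 3 `CCSc1ccc(C2C(Oc3ccccc3)C(=O)N2c2cc(OC)c(OC)c(OC)c2)cc1` gives 632 nM.

Compound 2 has the second highest number of the three. Its nearest neighbour is compound 3, which lies within the scatter of it, and its furthest is compound 1, whose number is far lower, well beyond the scatter. For the measured compounds named here, the only measured step, a 1.6-fold higher number from compound 2 to compound 3 (0.21 log units; within the scatter), swaps one group on the aromatic ring and changes little.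

Compound 4 `C=CC1C(=O)N(c2cc(OC)c(OC)c(OC)c2)C1c1ccc(OCC)cc1` differs from compound 2 in one place: vinyl in place of phenoxy on a saturated ring carbon. Going by the values given here, no measured step isolates this change. The nearest guide is compound 1, which also carries a vinyl group on the four-membered ring, but it differs from compound 2 in a second place as well, so its low number can only be read as a hint rather than a step. On that hint, compound 4 is expected to sit much closer to compound 1 than to compound 2 in this assay, so the expected step from compound 2 is a 19-fold lower number from compound 2 to compound 4 (1.29 log units; beyond the scatter). Compound 4 is therefore estimated at 20 nM, with a likely range from 5 nM to 80 nM.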

Compound 4, half-maximal inhibitory concentration: 97 nM
Estimate against measurement, compound 4: 4.9-fold (0.69 log units) below; measured number above the stated range.
By their numbers in this assay, from the lowest: compound 1; then compound 4; then compounds 2 and 3 (each within the scatter of the next).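

In this assay, the group on the saturated ring carbon of the four-membered ring clearly matters: with the 4-ethoxyphenyl group held the same, exchanging phenoxy for the much smaller vinyl gives a 4.0-fold lower number from compound 2 to compound 4 (0.60 log units; beyond the scatter), a modest gain in potency that lies beyond the scatter. Vinyl alone does not bring the number down to that of compound 1, however: a single methyl in place of hydrogen on the saturated chain carbon bound to an oxygen on an aromatic ring gives a 9.7-fold higher number from compound 1 to compound 4 (0.99 log units; beyond the scatter), so the size of this alkoxy group on the aromatic ring also counts once vinyl is present. Nothing available explains why either change has the effect it does.

On these data alone, what an ethyl chain, a hydroxyl group or an amine would do on the same ring carbon remains open, so these compounds show only two points, phenoxy and vinyl, at this position. As far as these compounds go, it is also open whether ethylsulfanyl, which made little difference alongside phenoxy, would behave the same way alongside vinyl.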